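The source may hold more compounds than are shown below. What is called first, only, known or untested is meant among the compounds shown, and "the series" means these compounds.

Compound 1 `O=C(O)c1cccc(-c2cnc(CCCc3ccc(-c4ccccc4)cc3)o2)n1` gives 10000 nM in an assay for inhibition of Fatty-acid amide hydrolase 1 (Rattus norvegicus); a higher number here means a weaker inhibitor, a lower number a stronger inhibitor. Compound 2 `O=C(O)c1ccc(-c2cnc(CCCc3ccc(-c4ccccc4)cc3)o2)nc1` gives 20000 nM in this assay, and the step of a 2.0-fold higher number from compound 1 to compound 2 (0.30 log units; within the scatter) lies within the scatter, so compound 2 stands alongside compound 1 rather than apart from it. Compound 3 `COC(=O)c1ccc(-c2cnc(CCCc3ccc(-c4ccccc4)cc3)o2)nc1` differs from compound 2 by methyl in place of hydrogen on an oxygen next to a carbonyl group. Within the data shown here, no measured step touches this change; the only step measured, a 2.0-fold higher number from compound 1 to compound 2 (0.30 log units; within the scatter), concerns the move from 6-carboxypyridin-2-yl to 5-carboxypyridin-2-yl. Compound 3 is therefore expected to show no step beyond the scatter, a 1.3-fold lower number from compound 2 to compound 3 (0.12 log units; within the scatter). The estimate for compound 3 in this assay is 15000 nM, ranging from 4000 nM to 50000 nM.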

Compound 3, inhibition constant: 50000 nM
Beside the measured number, compound 3's estimate is 3.3-fold (0.52 log units) below it; low and high end bracket the measured number.
By their numbers in this assay, from the lowest: compounds 1 and 2 (each within the scatter of the next); then compound 3.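

Among these compounds, replacing hydrogen with methyl on this oxygen is the first change in this assay to move the number beyond the scatter, with a 2.5-fold higher number from compound 2 to compound 3 (0.40 log units; beyond the scatter). Set against the other carboxylic acid, the 5-(methoxycarbonyl)pyridin-2-yl group gives a 5.0-fold higher number from compound 1 to compound 3 (0.70 log units; beyond the scatter), so among these three compounds the methyl ester has the highest number, although both steps are modest. Nothing available bears on what lies behind this rise. The compounds shown leave open whether an ethyl ester, an amide or a nitrile at this place would give a number nearer that of the carboxylic acids or that of the methyl ester.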